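Swapping cyclohexyl for a hydroxypyridinylmethyl arm

The source may hold more compounds than are shown below. What is called first, only, known or untested is meant among the compounds shown, and "the series" means these compounds.

Compound 2 `O=C(Nc1ccc(NC2CCCCC2)cc1Cl)c1cc(Cl)ccc1O` stands highest of the three compounds measured in an ADME assay on A549 cells (Homo sapiens) for cytotoxicity, read by resazurin assay, with a stated time of 48 h (a higher number here means that more compound is tolerated, a lower number that less compound is tolerated), giving 68300 nM. Compound 1 `CCCNc1ccc(NC(=O)c2cc(Cl)ccc2O)c(Cl)c1` gives 22500 nM, and compound 3 `O=C(Nc1ccc(NCc2cccc(C(F)(F)F)c2)cc1Cl)c1cc(Cl)ccc1O` gives 13300 nM. Compound 4 `O=C(Nc1ccc(NCc2ccc(O)nc2)cc1Cl)c1cc(Cl)ccc1O` differs from compound 2 in one place: (6-hydroxypyridin-3-yl)methyl in place of cyclohexyl on a nitrogen on an aromatic ring. Among the measured compounds shown here, two measured steps bear on this change. The step of a 3.0-fold higher number from compound 1 to compound 2 (0.48 log units; beyond the scatter) shows that the arrival of cyclohexyl raised the number, so its departure may give part of that back. The step of a 1.7-fold lower number from compound 1 to compound 3 (0.23 log units; within the scatter) shows that placing an aromatic ring on the chain carbon bound to the ring nitrogen changed little. A modest drop is therefore expected, a 2.7-fold lower number from compound 2 to compound 4 (0.44 log units; beyond the scatter). Compound 4 is estimated at 25000 nM, with a range from 8000 nM to 70000 nM.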

Compound 4, half-maximal cytotoxic concentration: 98500 nM
The estimate for compound 4 lay 3.9-fold (0.60 log units) below the measured number; measured number above the stated range.
By their numbers in this assay, from the lowest: compounds 3 and 1 (each within the scatter of the next); then compounds 2 and 4 (each within the scatter of the next).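

At this nitrogen, cyclohexyl and (6-hydroxypyridin-3-yl)methyl cannot be told apart in this assay with a 1.4-fold higher number from compound 2 to compound 4 (0.16 log units; within the scatter) as their step. An aromatic arm need not lower the number, and the choice of aromatic ring counts: a 7.4-fold higher number from compound 3 to compound 4 (0.87 log units; beyond the scatter) separates the two aromatic arms, while a 4.4-fold higher number from compound 1 to compound 4 (0.64 log units; beyond the scatter) sets the new arm clear of propyl. Nothing available explains these steps. Still open, on these data alone, is how a plain benzyl arm or a pyridin-3-ylmethyl arm without the hydroxyl would read, and so which part of the new arm goes with the higher number.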